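This account rests on a few compounds, and the source may have more. Where it says the series, first, only, none or still open, it means among the compounds named here.

Of the compounds shown here, three built on one shared core have been measured in an assay on RBL-1 cells with Polyunsaturated fatty acid 5-lipoxygenase (Rattus norvegicus) as the target; on this read-out higher numbers stand for weaker inhibition and lower numbers for stronger inhibition. Compound 1 `C=CCc1ccc2ccccc2c1O` gives 56 nM. Compound 2 `COc1ccc(Cc2ccc3ccccc3c2O)cc1` gives 75 nM. Compound 3 `CCOc1ccc(Cc2ccc3ccccc3c2O)cc1` gives 62 nM. Among the compounds with values here, only one pair among them differs in a single place, and that pair shows a 1.2-fold lower number from compound 2 to compound 3 (0.08 log units; within the scatter). Compound 3 thus stands second highest of the three numbers, yet its gaps to compound 1 and to compound 2 both lie within the scatter, so nothing separates these three compounds with confidence.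

Compound 4 `CSc1ccc(Cc2ccc3ccccc3c2O)cc1` has not yet been measured. It differs from compound 3 in that (methylsulfanyl in place of ethoxy on an aromatic carbon). Within the data shown here, no measured step puts methylsulfanyl in place of ethoxy, so the only guidance is indirect: the single measured step, which lengthened the chain on the oxygen at this same place, stayed within the scatter, and the three measured compounds, despite carrying quite different groups, sit close together. On that basis a step of no more than the scatter, in no particular direction, is expected in this assay, and the estimated step is a 1.0-fold lower number from compound 3 to compound 4 (0.01 log units; within the scatter). Compound 4 is therefore expected at about 60 nM, with a range from 25 nM to 150 nM.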

Compound 4, half-maximal inhibitory concentration: 48 nM
Compound 4: the middle estimate sits 1.3-fold (0.10 log units) above what was measured, within the range that was stated.
By their numbers in this assay, from the lowest: compounds 4, 1, 3 and 2 (each within the scatter of the next).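

Compound 4 puts a sulfur atom where compound 2 and compound 3 carry an oxygen, and the replacement gives a 1.3-fold lower number from compound 3 to compound 4 (0.11 log units; within the scatter) when it takes the place of ethoxy and a 1.6-fold lower number from compound 2 to compound 4 (0.19 log units; within the scatter) when it takes the place of methoxy, so in this assay it does not separate compound 4 from either of them. Taken with the earlier step on the oxygen chain, this shows that, among methoxy, ethoxy and methylsulfanyl on this aromatic carbon, neither the linking atom nor the extra carbon on the chain has produced a step beyond the scatter. Nothing shown here explains why these groups read alike.

These three groups are much alike in size and all hold a single hydrogen-bond acceptor, so they test only a narrow part of what this place might accept. As far as these compounds go, how an amine, a carboxylic acid, a chlorine atom or a longer chain such as butoxy would read here remains open, as does whether a sulfur atom on a longer chain would match the result for methylsulfanyl.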